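Heteroaryl replacement on the shared core: outlook for compound 4

The compounds below may be only part of what the source reports. "The series", "measured", "known", "first", "only" and "open" are said of these compounds alone.

Three acids built on one shared core have numbers in an in vitro functional assay on HEK285-7 cells for antagonist activity at prostaglandin D2 receptor 2 (Homo sapiens), read by BRET and beta-arrestin recruitment; on this read-out lower numbers stand for stronger inhibition and higher numbers for weaker inhibition. Compound 1 `O=C(O)Cc1sc(NCc2ccccc2)nc1-c1ccc(Cl)cc1` gives 2300 nM. Compound 2 `O=C(O)Cc1sc(C(c2ccc(F)cc2)c2ccc(F)cc2)nc1-c1ccoc1` gives 130 nM. Compound 3 `O=C(O)Cc1sc(C(c2ccc(F)cc2)c2ccc(F)cc2)nc1-c1cn[nH]c1` gives 220 nM. Going by the values given here, compound 3 thus stands second highest of the three numbers; its nearest neighbour is compound 2, and the single step between them, a 1.7-fold higher number from compound 2 to compound 3 (0.23 log units; within the scatter), lies within the scatter. Among the compounds with values here, compound 1 sits furthest off, with a higher number beyond the scatter, but it differs from compound 3 in more than one place, so no single step is drawn between the two.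

Compound 4 `O=C(O)Cc1sc(C(c2ccc(F)cc2)c2ccc(F)cc2)nc1-c1ccnc(O)c1` is not yet measured. It differs from compound 3 in one place: 2-hydroxypyridin-4-yl in place of 1H-pyrazol-4-yl on an aromatic carbon. Within the data shown here, the only measured step that bears on this change is an exchange of one heteroaryl group for another at the same carbon, a 1.7-fold higher number from compound 2 to compound 3 (0.23 log units; within the scatter), which stayed within the scatter. On that basis the step from compound 3 to compound 4 is expected to stay within the scatter as well, with no set direction. Compound 4 is therefore estimated at 200 nM in this assay, with a range from 70 nM to 600 nM. The expected step is a 1.1-fold lower number from compound 3 to compound 4 (0.04 log units; within the scatter).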

Compound 4, half-maximal inhibitory concentration: 890 nM
Compound 4: middle estimate off by 4.5-fold (0.65 log units), on the low side, and the stated range ends below it.
By their numbers in this assay, from the lowest: compounds 2 and 3 (each within the scatter of the next); then compound 4; then compound 1.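

In this assay this aromatic carbon, next to the ring nitrogen and next to the ring atom that bears the carboxymethyl group, no longer looks indifferent to heteroaryl exchange: 2-hydroxypyridin-4-yl in place of 1H-pyrazol-4-yl gives a 4.0-fold higher number from compound 3 to compound 4 (0.61 log units; beyond the scatter) and so passes beyond the scatter, which the earlier exchange, a 1.7-fold higher number from compound 2 to compound 3 (0.23 log units; within the scatter), did not. The loss does not depend on which five-membered group serves as the reference, since 2-hydroxypyridin-4-yl in place of furan-3-yl gives a 6.8-fold higher number from compound 2 to compound 4 (0.84 log units; beyond the scatter) on the same shared core. Among these three compounds, the two five-membered aromatic rings stay within the scatter of each other and the one six-membered aromatic ring, the larger group with the added hydrogen-bond acceptor, stands apart with a weaker number, though a single compound carries that reading.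

Still open, on these data alone, is whether the rise belongs to the six-membered ring itself or to its hydroxy group, and a plain pyridin-4-yl or a 2-methoxypyridin-4-yl at this carbon would separate the two. Nothing at hand gives a reason for the rise.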